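A few compounds are considered here, and "the series" means these few. Any claim that something is new, unique, unknown or untested is made for them only; others in the source may bear on it.

Measured compounds:
Compound 1, `COc1cc(-c2nnc3n2NC(c2cccs2)C(C(=O)c2ccccc2)S3)cc(OC)c1OC`: in a functional assay on MCF7 cells (Homo sapiens) for cytotoxicity, read by MTT assay, with a stated time of 48 h (on this read-out higher numbers stand for weaker inhibition and lower numbers for stronger inhibition), compound 1 gives > 100000 nM, which is a limit of the assay and not a number.
Compound 2, `COc1ccc(C(=O)C2Sc3nnc(-c4cc(OC)c(OC)c(OC)c4)n3NC2c2ccco2)cc1`: in this assay compound 2 gives > 100000 nM, again a limit and not a number.

Among the measured compounds shown here, compound 1 thus stands at no measured point on this read-out; its value is only a limit, and the one other value shown is a limit too, so that (the limit of > 100000 nM in this assay, at which 2 of the 2 values shown sit). Compound 3, `COc1cc(-c2nnc3n2NC(c2cccs2)C(C(=O)c2ccc(Cl)cc2)S3)cc(OC)c1OC`, differs from compound 1 in a single place: chloro in place of hydrogen on an aromatic carbon. For the measured compounds named here, no step between two measured compounds is available to gauge a change of this kind. Because (the limit of > 100000 nM in this assay, at which 2 of the 2 values shown sit), the step of a number no higher from compound 1 to compound 3 (the limit leaves the size open) is expected to be none beyond the scatter, with the result most likely remaining a limit. Compound 3 is therefore estimated to give 100000 nM in this assay, within a range from 20000 nM to 300000 nM.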

Compound 3, half-maximal inhibitory concentration: 42800 nM
Compound 3: middle estimate off by 2.3-fold (0.37 log units), on the high side, and the stated range covers the measured number.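

In this assay, chloro in place of hydrogen on this six-membered aromatic ring, the change from phenyl to 4-chlorophenyl, gives an at least 2.3-fold lower number from compound 1 to compound 3 (0.36 log units; beyond the scatter). Among the compounds shown here, this is the first sign that this place on the molecule can affect the read-out, and the change moves the result from a limit to a measured number. The size of the step is only a lower bound, as the value of compound 1 is a limit and not a number, and such limits still make up most of the data: the limit of > 100000 nM in this assay, at which 2 of the 3 values shown sit.

The compounds shown do not tell whether this shift is specific to chloro or would also appear with another group at this place, such as fluoro, methoxy or an amine. They also leave open what chloro would do at other places on this ring.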